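The source may hold more compounds than are shown below. What is called first, only, known or untested is meant among the compounds shown, and "the series" means these compounds.

Of the compounds shown here, three of a shared core have been measured so far in a functional assay on HEK293 cells with D(4) dopamine receptor (Homo sapiens) as the target, read by FLIPR; a higher number here means a larger maximal response, a lower number a smaller maximal response. Going by the values given here, compound 1 `CO/N=C(/CCN1CCN(c2ccccn2)CC1)c1ccccc1Cl` gives 73%, and compound 2 `CO/N=C(/CCN1CCN(c2ccccn2)CC1)c1ccc(Cl)cc1` gives 68%; the only single change among them, 4-chlorophenyl in place of 2-chlorophenyl on a carbon with a double bond to nitrogen, gives a number 5 percentage points lower from compound 1 to compound 2 (within the scatter). Compound 3 `CO/N=C(\CCN1CCN(c2ccccn2)CC1)c1ccc(Cl)cc1Cl` gives 78%, a number that sits alongside the other two, within the usual scatter of each of them.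

Compound 4 `CO/N=C(/CCN1CCN(c2ccccn2)CC1)c1ccc(Cl)cc1Cl` is the companion of compound 3: the two compounds have the same atoms and bonds and differ only in configuration as drawn: 1 of 1 stereo elements differ; a double bond is drawn E in compound 3 and Z in compound 4. Among the compounds with values here, no measured pair differs in this way, so nothing already seen bears directly on the step. Within the data shown here, the one step that exists changed where the chlorine sits, not how the double bond is drawn, and it stayed within the scatter. In the absence of any contrary sign, the expected step is a number 3 percentage points lower from compound 3 to compound 4 (within the scatter), that is, none beyond the scatter. Compound 4 is therefore estimated at 75%, with a range from 58% to 90%.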

Compound 4, largest response reached (reported as efficacy), in percent of the reference or control that the assay uses: 65%
Compound 4: middle estimate off by 10 percentage points, on the high side, and the stated range covers the measured number.
By their numbers in this assay, from the lowest: compounds 4, 2, 1 and 3 (each within the scatter of the next, the first and the last beyond it).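

In this assay, going by these compounds alone, the way the double bond is drawn turns out to matter, which no earlier pair could show: a number 13 percentage points lower from compound 3 to compound 4 (beyond the scatter). Within the data shown here, this is the only step so far that lies beyond the scatter, and it can be traced to the double bond alone because of one structural fact: the fact that compounds 3 and 4 differ only in the configuration as drawn. Chloro in place of hydrogen on an aromatic carbon, by contrast, stays within the scatter in both available comparisons: a number 3 percentage points lower from compound 2 to compound 4 (within the scatter), and a number 8 percentage points lower from compound 1 to compound 4 (within the scatter).

On these data alone, this rests on a single pair, so it remains open whether the double bond carries a similar step when the phenyl ring holds only one chlorine. As far as these compounds go, it is also open how a fluoro or methoxy group in place of chloro would behave in either double-bond form.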